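The compounds below may be only part of what the source reports. "The series", "measured", "known", "first", "only" and "open" are said of these compounds alone.

Compound 2 `Nc1scc(CN2CCN(c3cc(F)ccc3F)CC2)c1C(=O)c1ccc(Cl)cc1` was tested in an assay on CHO cells for displacement of a labelled ligand from adenosine receptor A3 (Homo sapiens), read by scintillation counting, with a stated time of 120 min, tested at 10 uM (a lower number here means less inhibition, a higher number more inhibition at the concentration tested (going by the name of the read-out)), and gives 2%. Within the data shown here, compound 1 `CC(C)N1CCN(Cc2csc(N)c2C(=O)c2ccc(Cl)cc2)CC1`, the only other compound measured, gives 0% in this assay, so the two values lie within the usual scatter of each other. Compound 3 `Nc1scc(CN2CCN(c3ccc(F)c(Cl)c3)CC2)c1C(=O)c1ccc(Cl)cc1` carries 3-chloro-4-fluorophenyl in place of 2,5-difluorophenyl on an amine nitrogen in a ring. Among the measured compounds shown here, the one measured change on this ring nitrogen, a number 2 percentage points higher from compound 1 to compound 2 (within the scatter), bears on this step and stayed within the scatter, so no step beyond the scatter is expected in this assay. Compound 3 is therefore estimated at 3%, between -7% and 15%. The step of a number 1 percentage points higher from compound 2 to compound 3 (within the scatter) is expected to stay within the scatter.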

Compound 3, a percentage reported as inhibition, at one concentration (the size of the read-out at that concentration, not a potency): 0%
Compound 3: the middle estimate sits 3 percentage points above what was measured, and the stated range covers the measured number.
By their numbers in this assay, from the lowest: compounds 1, 3 and 2 (each within the scatter of the next).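

In this assay, 3-chloro-4-fluorophenyl in place of 2,5-difluorophenyl on this ring nitrogen gives a number 2 percentage points lower from compound 2 to compound 3 (within the scatter). Set against isopropyl, the same group gives no change at the digits printed from compound 1 to compound 3 (within the scatter), so the three groups on this nitrogen cannot be told apart in this measurement, and moving the halogens on the phenyl ring adds nothing beyond the scatter. Nothing available offers an explanation for this result. The compounds shown leave open whether a carboxylic acid or a longer alkyl chain on this nitrogen would move the inhibition beyond the scatter. Going by these compounds, whether a change elsewhere on the shared core would do so also remains open.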